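This account rests on a few compounds, and the source may have more. Where it says the series, first, only, none or still open, it means among the compounds named here.

Among the compounds with values here, compound 2 `O=S(=O)(Nc1ccccn1)c1ccc(Nc2nncc3ccccc23)cc1` gives 54 nM in a functional assay on DU-145 cells (Homo sapiens) for antiproliferative activity, read by sulforhodamine B assay, with a stated time of 72 h (a lower number here means a stronger inhibitor, a higher number a weaker inhibitor), and sits at the high end of the three numbers so far: compound 1 `Cc1cc(NS(=O)(=O)c2ccc(Nc3nncc4ccccc34)cc2)no1` gives 35 nM, and compound 3 `COc1ccc(NC(=S)NNc2nncc3ccccc23)cc1` gives 25 nM. Compound 4 `NS(=O)(=O)c1ccc(Nc2nncc3ccccc23)cc1` carries hydrogen in place of pyridin-2-yl on a sulfonamide nitrogen. Within the data shown here, the only step that bears on this position is a 1.5-fold higher number from compound 1 to compound 2 (0.19 log units; within the scatter), where one six-membered ring with one hetero atom replaced a five-membered one on the sulfonamide nitrogen with little effect. Among the measured compounds shown here, no measured step removes the substituent entirely, so the primary sulfonamide is untested. A modest shift is expected, most likely towards a higher number, with wide uncertainty. Compound 4 is therefore estimated at 90 nM, between 30 nM and 300 nM, an expected step of a 1.7-fold higher number from compound 2 to compound 4 (0.22 log units; within the scatter).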

Compound 4, half-maximal inhibitory concentration: 14 nM
Beside the measured number, compound 4's estimate is 6.4-fold (0.81 log units) above it, and the stated range ends above it.
By their numbers in this assay, from the lowest: compounds 4, 3, 1 and 2 (each within the scatter of the next, the first and the last beyond it).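

Hydrogen on the sulfonamide nitrogen gives a lower number than either ring, with a 3.9-fold lower number from compound 2 to compound 4 (0.59 log units; beyond the scatter) and a 2.5-fold lower number from compound 1 to compound 4 (0.40 log units; beyond the scatter) as the two steps. The earlier exchange of one ring for the other did not show this, since it stayed within the scatter. Neither ring is therefore needed on this nitrogen for activity in this assay among these compounds.

Open is whether a methyl or an acetyl on that nitrogen keeps the number of compound 4, and whether a plain phenyl ring matches the two rings shown. Nothing available explains the drop on removing the ring.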